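A few compounds are considered here, and "the series" means these few. Any claim that something is new, unique, unknown or untested is made for them only; others in the source may bear on it.

Notes on the series. In a functional assay on ECa-109 cells (Homo sapiens) for cytotoxicity, read by MTT assay, with a stated time of 48 h (on this read-out lower numbers stand for stronger inhibition and higher numbers for weaker inhibition), compound 3 `O=C1C(O)=C(C(c2ccc(F)cc2)c2c[nH]c3ccccc23)C(=O)c2ccccc21` gives 28100 nM, the highest of the two numbers in hand. Compound 1 `COc1cc(C(C2=C(O)C(=O)c3ccccc3C2=O)c2c[nH]c3ccc(Br)cc23)cc(OC)c1OC` gives 13000 nM, a lower number than compound 3 and beyond the scatter. Compound 2 `COc1ccccc1C(C1=C(O)C(=O)c2ccccc2C1=O)c1c[nH]c2ccccc12` is recorded only as a limit of this assay, > 200000 nM, which is the limit of > 200000 nM in this assay, at which 1 of the 3 values shown sits. Among the compounds with values here, the one step measured in a single place runs an at least 7.1-fold lower number from compound 2 to compound 3 (0.85 log units; beyond the scatter).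

Compound 4 `COc1ccc(C(C2=C(O)C(=O)c3ccccc3C2=O)c2c[nH]c3ccccc23)cc1Br` differs from compound 3 in one place: 3-bromo-4-methoxyphenyl in place of 4-fluorophenyl on a saturated chain carbon bound to an aromatic carbon and a double-bonded ring carbon. Within the data shown here, no measured step replaces one aromatic group on the saturated chain carbon by another while starting from a number; the step from compound 2 to compound 3 shows that a change of this group can move the read-out by a large amount, but it starts from a limit and sets no size for the present change. Compound 1 carries a different group at the same place and sits within a modest gap of compound 3, so a number of the same order is expected for compound 4. The step of a 1.4-fold lower number from compound 3 to compound 4 (0.15 log units; within the scatter) is therefore expected to stay close to the scatter, with a small chance of a lower number. For compound 4 the estimate in this assay is 20000 nM, with a range from 6000 nM to 70000 nM.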

Compound 4, half-maximal inhibitory concentration: 11800 nM
For compound 4 the middle estimate is 1.7-fold (0.23 log units) above the measured one; measured number inside the range.
By their numbers in this assay, from the lowest: compounds 4 and 1 (each within the scatter of the next); then compound 3. At a limit, above all of these: compound 2.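

In this assay, within the data shown here, the change from 4-fluorophenyl to 3-bromo-4-methoxyphenyl gives a 2.4-fold lower number from compound 3 to compound 4 (0.38 log units; beyond the scatter), the first step at this place that runs from one number to another, and it shows that a number can still move beyond the scatter when both ends are measured. A methoxy group on the aromatic ring at this place does not by itself go with the weak end of the series: 3-bromo-4-methoxyphenyl in place of 2-methoxyphenyl gives an at least 16-fold lower number from compound 2 to compound 4 (1.22 log units; beyond the scatter). Compound 2 is recorded only as a limit, so that step has a lower bound and no fixed size: the limit of > 200000 nM in this assay, at which 1 of the 4 values shown sits.

The compounds shown do not separate the bromine from the methoxy group in 3-bromo-4-methoxyphenyl, so it stays open which of the two goes with the lower number in compound 4. Going by these compounds, it also stays open whether an aromatic group is needed on the saturated chain carbon at all, or whether a non-aromatic group such as a morpholine or a carboxylic acid on a short chain would hold a number of this order.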